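An Oxazole in Place of the Carbamoyl Group

This account rests on a few compounds, and the source may have more. Where it says the series, first, only, none or still open, it means among the compounds named here.

Measured in an assay on A10 cells for binding affinity to Endothelin-1 receptor (Rattus norvegicus); on this read-out lower numbers stand for stronger inhibition and higher numbers for weaker inhibition:
Compound 1, `Cc1ccccc1C(CCC(=O)O)Oc1cccc(OCc2ccsc2)c1`, gives 871 nM.
Compound 2, `CC(=O)c1ccc(OCc2ccsc2)cc1OC(CCC(=O)O)c1ccccc1C`, gives 26 nM.
Compound 3, `Cc1ccccc1C(CCC(=O)O)Oc1cc(OCc2ccsc2)ccc1C(N)=O`, gives 29 nM.

Compound 3 stands close to compound 2 and far from compound 1: the step of a 1.1-fold higher number from compound 2 to compound 3 (0.05 log units; within the scatter) stays within the scatter, whereas a 30-fold lower number from compound 1 to compound 3 (1.48 log units; beyond the scatter) is large. Compound 4, `Cc1ccccc1C(CCC(=O)O)Oc1cc(OCc2ccsc2)ccc1-c1ncco1`, differs from compound 3 in one place: 1,3-oxazol-2-yl in place of carbamoyl on an aromatic carbon.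

Going by the values given here, two measured steps bear on this change. The step of a 30-fold lower number from compound 1 to compound 3 (1.48 log units; beyond the scatter) shows that a carbamoyl group at this aromatic carbon, compared with hydrogen, brings a large gain, and a 34-fold lower number from compound 1 to compound 2 (1.53 log units; beyond the scatter) shows the same for an acetyl group. The step of a 1.1-fold higher number from compound 2 to compound 3 (0.05 log units; within the scatter) shows that exchanging one of these groups for the other changes little. Among the compounds with values here, no measured step tests a ring at this carbon, nor the loss of the hydrogen-bond donor. Since compound 4 keeps a substituent at this carbon, the step of a 1.4-fold higher number from compound 3 to compound 4 (0.14 log units; within the scatter) is expected to be modest, probably within or only slightly beyond the scatter. Compound 4 is therefore estimated at 40 nM in this assay, with a range of 10 nM to 200 nM.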

Compound 4, half-maximal inhibitory concentration: 20 nM
For compound 4 the middle estimate is 2.0-fold (0.30 log units) above the measured one, and the stated range covers the measured number.
By their numbers in this assay, from the lowest: compounds 4, 2 and 3 (each within the scatter of the next); then compound 1.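

In this assay, the aromatic carbon para to the (thiophen-3-yl)methoxy group accepts a five-membered aromatic ring as readily as the open-chain groups: a 1.5-fold lower number from compound 3 to compound 4 (0.16 log units; within the scatter) and a 1.3-fold lower number from compound 2 to compound 4 (0.11 log units; within the scatter) both stay within the scatter, while a 44-fold lower number from compound 1 to compound 4 (1.64 log units; beyond the scatter) keeps the large gain over hydrogen. The hydrogen-bond donor of the carbamoyl group is therefore not needed for this level of inhibition in the present series, since the 1,3-oxazol-2-yl group carries none, and the greater number of heavy atoms in that group brings no measurable loss. Nothing available explains why these three different substituents give such similar numbers.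

The compounds shown leave open whether the gain depends on the hetero atoms of the substituent, as neither a plain phenyl ring nor a simple methyl group appears at this carbon. They also leave open how far the ring can be varied, for instance with a 1,3-thiazol-2-yl group, a six-membered pyridyl ring or a 1,3-oxazol-2-yl group bearing a methyl substituent.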